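Swapping the nitrogen substituent: compound 3 to compound 4

The source may hold more compounds than are shown below. What is called first, only, known or untested is meant among the compounds shown, and "the series" means these compounds.

The series shares a core with two ring oxygens and an aryl sulfone. Compound 1 `CC(C)OC(=O)N1CCC(O[C@H]2CC[C@H](Oc3ccc(S(C)(=O)=O)nc3)CC2)CC1` gives 13 nM in a functional assay on isolated protein for agonist activity at Glucose-dependent insulinotropic receptor (Homo sapiens), read by HTRF and cAMP accumulation; a higher number here means that more compound is needed for the effect, a lower number that less compound is needed. Compound 2 `CC(C)S(=O)(=O)c1cnc(O[C@H]2CC[C@H](OC3CCN(C(=O)OC(C)(C)C)CC3)CC2)cn1` gives 18.5 nM in this assay. Compound 3 `CC(C)OC(=O)N1CCC(O[C@H]2CC[C@H](Oc3cnc(S(C)(=O)=O)cn3)CC2)CC1` gives 13.7 nM in this assay. Among the measured compounds shown here, the one single-point step measured so far, a 1.1-fold higher number from compound 1 to compound 3 (0.02 log units; within the scatter), shows that exchanging the aryl ring leaves the number essentially unchanged. For the measured compounds named here, compound 3 thus stands in the middle of a tight cluster: compound 1 is within the scatter on one side, compound 2 within the scatter on the other, and no compound can be called more or less potent than another.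

Compound 4 `CS(=O)(=O)c1cnc(O[C@H]2CC[C@H](OC3CCN(CC4(C(F)(F)F)CCC4)CC3)CC2)cn1` is the next step from compound 3. The change is (1-(trifluoromethyl)cyclobutyl)methyl in place of isopropoxycarbonyl on an amine nitrogen in a ring. Going by the values given here, no measured step touches this position: compounds 1, 2 and 3 all carry an alkoxycarbonyl on that ring nitrogen, and the only step on record concerns the aryl ring. The expectation for compound 4 therefore rests on the absence of any precedent rather than on a trend, and the step of a 1.5-fold higher number from compound 3 to compound 4 (0.16 log units; within the scatter) is expected to stay within the scatter, with a wide range to reflect the uncertainty. Compound 4 is estimated at 20 nM in this assay, between 5 nM and 80 nM.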

Compound 4, half-maximal effective concentration: 54.8 nM
For compound 4 the middle estimate is 2.7-fold (0.44 log units) below the measured one; the range from low to high includes it.
By their numbers in this assay, from the lowest: compounds 1, 3 and 2 (each within the scatter of the next); then compound 4.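

Among the compounds shown here, the ring nitrogen is the first position where a change moves the number beyond the scatter: in this assay the step is a 4.0-fold higher number from compound 3 to compound 4 (0.60 log units; beyond the scatter), whereas the exchange of the aryl ring gave a 1.1-fold higher number from compound 1 to compound 3 (0.02 log units; within the scatter). The alkoxycarbonyl shared by compounds 1, 2 and 3 is therefore not required for a measurable effect, since (1-(trifluoromethyl)cyclobutyl)methyl, which has no carbonyl and no hydrogen-bond acceptors, still gives a modest loss rather than a collapse of the read-out. No measurement at hand accounts for the size of this step.

The change removes the carbamate and brings in the four-membered ring and the trifluoromethyl in a single move, so the compounds shown cannot assign the step to any one of these parts. As far as these compounds go, it remains open whether a plain cyclobutylmethyl without the fluorines, or an amide or urea on the same ring nitrogen, would stay within the scatter of compound 3 or follow compound 4.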